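Swapping the benzyl for a dimethylisoxazolylmethyl on the sulfonamide

A few compounds are considered here, and "the series" means these few. Any claim that something is new, unique, unknown or untested is made for them only; others in the source may bear on it.

Within the data shown here, in an assay on cells for binding affinity to prostaglandin D2 receptor 2 (Homo sapiens), read by radioligand binding (on this read-out lower numbers stand for stronger inhibition and higher numbers for weaker inhibition), compound 2 `O=C(O)Cn1cc(C2c3ccccc3S(=O)(=O)N2Cc2ccccc2)c2ccccc21` gives 1100 nM, the weaker of the two numbers measured so far. Compound 1 `Cc1c(C2NS(=O)(=O)c3ccccc32)c2cc(F)ccc2n1CC(=O)O` gives 430 nM in this assay, a gap beyond the usual scatter. Compound 3 `Cc1noc(C)c1CN1C(c2cn(CC(=O)O)c3ccccc23)c2ccccc2S1(=O)=O` differs from compound 2 in one place: 3,5-dimethyl-1,2-oxazol-4-yl in place of phenyl on a saturated chain carbon bound to a sulfonamide nitrogen in a ring. Among the measured compounds shown here, no step between measured compounds shows what such a swap does here, so the expectation rests on the otherwise unchanged structure of compound 2. A step of a 1.1-fold lower number from compound 2 to compound 3 (0.04 log units; within the scatter) is expected, within the scatter and in no certain direction. Compound 3 is estimated at 1000 nM, within a range from 300 nM to 3500 nM.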

Compound 3, inhibition constant: 18 nM
For compound 3 the middle estimate is 56-fold (1.74 log units) above the measured one, outside the stated range (below it).
By their numbers in this assay, from the lowest: compound 3; then compound 1; then compound 2.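

The group on a saturated chain carbon bound to a sulfonamide nitrogen in a ring strongly affects the result in this assay: replacing phenyl with 3,5-dimethyl-1,2-oxazol-4-yl gives a 61-fold lower number from compound 2 to compound 3 (1.79 log units; beyond the scatter). This single change brings in a five-membered aromatic ring with 2 hetero atoms and 2 hydrogen-bond acceptors. No measurement available here accounts for the size of this step.

From the compounds shown here alone, a plain 1,2-oxazol-4-yl without the two methyl groups, or a pyridinyl ring, remains open at this position. So does the effect of the same swap on the core of compound 1.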